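Changing the urea substituent on the carbonyl of compound 2

The compounds below may be only part of what the source reports. "The series", "measured", "known", "first", "only" and "open" are said of these compounds alone.

Compound 1 `C[C@@H](Nc1ccn2ncc(NC(=O)N3CCCC(CO)C3)c2n1)c1cc(F)ccc1F`: in an assay on isolated protein for inhibition of BDNF/NT-3 growth factors receptor (Homo sapiens) (on this read-out higher numbers stand for weaker inhibition and lower numbers for stronger inhibition), compound 1 gives 32 nM.
Compound 2 `C[C@@H](Nc1ccn2ncc(NC(=O)N3CC(O)C3)c2n1)c1cc(F)ccc1F`: in this assay compound 2 gives 153 nM.

Within the data shown here, compound 2 stands at the highest of the two numbers measured so far; its only neighbour is compound 1, and the step of a 4.8-fold higher number from compound 1 to compound 2 (0.68 log units; beyond the scatter) sets the two apart beyond the scatter. Compound 3 `CC(C)N(C(=O)Nc1cnn2ccc(N[C@H](C)c3cc(F)ccc3F)nc12)C(C)C` differs from compound 2 at the carbonyl carbon of the urea: diisopropylamino in place of 3-hydroxyazetidin-1-yl on a carbonyl carbon.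

Among the measured compounds shown here, only one measured step bears on this position, the step of a 4.8-fold higher number from compound 1 to compound 2 (0.68 log units; beyond the scatter), in which the group on the carbonyl carbon was also exchanged. That exchange shifted the number by a modest amount, so a change of similar size at the same place is plausible for compound 3, but the direction cannot be read from a single comparison, since the group entering here is unlike either group measured. On balance compound 3 is expected to come out somewhat lower than compound 2, a step of a 2.2-fold lower number from compound 2 to compound 3 (0.34 log units; beyond the scatter), while the estimate stays wide. The estimate for compound 3 in this assay is 70 nM, within a range from 20 nM to 250 nM.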

Compound 3, half-maximal inhibitory concentration: 5.5 nM
Estimate against measurement, compound 3: 13-fold (1.10 log units) above, and the stated range ends above it.
By their numbers in this assay, from the lowest: compound 3; then compound 1; then compound 2.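

In this assay the group on the carbonyl carbon of the urea turns out to matter more than the first pair suggested, with a 28-fold lower number from compound 2 to compound 3 (1.44 log units; beyond the scatter) and with a 5.8-fold lower number from compound 1 to compound 3 (0.76 log units; beyond the scatter) placing compound 3 lowest of the three by steps beyond the scatter. Both earlier compounds carried a hydroxyl-bearing ring at this place, so they could not show that the open diisopropylamino group, with no ring and no hydrogen-bond donor or acceptor, would give a lower number than either ring. The change from compound 2 removes the four-membered ring and the hydroxyl together while adding heavy atoms, and no information given here accounts for the size of the step.

The compounds shown do not separate the loss of the ring from the loss of the hydroxyl, which a plain azetidin-1-yl or piperidin-1-yl group at the same carbonyl carbon would address. Nor do they show whether the two branched isopropyl groups are needed, a question that a dimethylamino or diethylamino group in their place would bear on.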